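A few compounds are considered here, and "the series" means these few. Any claim that something is new, unique, unknown or untested is made for them only; others in the source may bear on it.

Measured compounds and their values in a functional assay on BGC-823 cells (Homo sapiens) for antiproliferative activity, read by MTT assay, tested at 1 uM; on this read-out lower numbers stand for a weaker effect and higher numbers for a stronger effect at the one concentration tested:
compound 1 `COc1cc(C(=O)N/N=C/c2ccccc2F)cc(OC)c1OC`, 51.6%
compound 2 `COc1cc(C(=O)N/N=C/c2ccc(F)c(F)c2)cc(OC)c1OC`, 33.1%
compound 3 `COc1cc(C2=NN(C(C)=O)C(c3ccc(F)cc3)O2)cc(OC)c1OC`, -0.4%

Compound 3 stands lowest of the three numbers in this assay, beyond the scatter under both compound 2 and compound 1; its value means essentially no effect at the tested concentration. Compound 4 `COc1cc(C2=NN(C(C)=O)C(c3cccc(C(F)(F)F)c3)O2)cc(OC)c1OC` differs from compound 3 in one place: 3-(trifluoromethyl)phenyl in place of 4-fluorophenyl on a saturated ring carbon.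

Among the compounds with values here, only one measured step exists, a number 18.5 percentage points lower from compound 1 to compound 2 (beyond the scatter), and it concerns a fluorine pattern on a different core, so it bears on the present change only loosely; it shows that altering the fluorine substitution of the phenyl ring produced a modest decrease there. Nothing measured shows a trifluoromethyl group on the core of compound 3. The expectation for compound 4 is therefore a step of about a number 5.4 percentage points higher from compound 3 to compound 4 (within the scatter), not beyond the scatter. For compound 4 the estimated value in this assay is 5%, with a range from -15% to 30%.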

Compound 4, a percentage reported as inhibition, at one concentration (the size of the read-out at that concentration, not a potency): 27.9%
Compound 4: middle estimate off by 22.9 percentage points, on the low side; the measured number falls inside the stated range.
By their numbers in this assay, from the lowest: compound 3; then compounds 4 and 2 (each within the scatter of the next); then compound 1.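

In this assay, putting 3-(trifluoromethyl)phenyl in place of 4-fluorophenyl on the saturated ring carbon gives a number 28.3 percentage points higher from compound 3 to compound 4 (beyond the scatter), so the group at this carbon can decide whether the shared core shows an effect at the tested concentration. This swap alters both the substituent on the phenyl ring and its place on that ring, and this single pair cannot tell those two changes apart. Nothing available explains why the number rises.

The compounds shown leave open how a phenyl ring carrying a nitrile, a methoxy group or an amine would behave at this same carbon. They also leave open whether the 3-(trifluoromethyl)phenyl result would hold if a longer acyl chain replaced the acetyl group on the ring nitrogen.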